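The source may hold more compounds than are shown below. What is called first, only, known or untested is meant among the compounds shown, and "the series" means these compounds.

Measured compounds:
compound 1, `Cc1cc(Nc2ccn(Cc3cccc4ccccc34)n2)n2nc(SCc3ccc(Br)cc3)nc2n1`, 4310 nM
compound 2, `Cc1cc(Nc2cc(-c3ccccc3)[nH]n2)n2nc(SCc3ccc(F)cc3)nc2n1`, 4020 nM
compound 3, `Cc1cc(Nc2ccn(Cc3ccc(C(F)(F)F)cc3)n2)n2nc(SCc3ccc(Br)cc3)nc2n1`, 2280 nM

All three were tested in a functional assay on MCF7 cells (Homo sapiens) for inhibition, read by MTT assay, with a stated time of 72 h; on this read-out lower numbers stand for stronger inhibition and higher numbers for weaker inhibition. Among these numbers compound 2 sits between compound 1 and compound 3, and its gap to each of them lies within the scatter of the measurement, so the three compounds cannot be told apart on the values shown.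

Compound 4, `C#CCSc1nc2nc(C)cc(Nc3cc(-c4ccccc4)[nH]n3)n2n1`, has not yet been measured. It differs from compound 2 in one place: ethynyl in place of 4-fluorophenyl on a saturated chain carbon bound to a sulfur. Among the compounds with values here, the only step measured so far, a 1.9-fold lower number from compound 1 to compound 3 (0.28 log units; within the scatter), concerns a different part of the molecule, the group on the saturated chain carbon bound to an aromatic nitrogen, and it stayed within the scatter. Within the data shown here, no measured pair changes the group on the saturated chain carbon bound to a sulfur, so the data give no direct guide to the step from compound 2 to compound 4. Given that the one change tried elsewhere did nothing beyond the scatter, the account expects a 1.5-fold higher number from compound 2 to compound 4 (0.17 log units; within the scatter) to stay small as well, with a wide margin of uncertainty. For compound 4 the estimated value is 6000 nM, within a range from 2000 nM to 20000 nM.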

Compound 4, half-maximal inhibitory concentration: 21800 nM
For compound 4 the middle estimate is 3.6-fold (0.56 log units) below the measured one; measured number outside the range, above it.
By their numbers in this assay, from the lowest: compounds 3, 2 and 1 (each within the scatter of the next); then compound 4.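

In this assay, the group on the saturated chain carbon bound to a sulfur proves to be a place where a single change registers: the swap of 4-fluorobenzyl for propargyl gives (a 5.4-fold higher number from compound 2 to compound 4 (0.73 log units; beyond the scatter)) and lies beyond the scatter, unlike the change on the saturated chain carbon bound to an aromatic nitrogen (a 1.9-fold lower number from compound 1 to compound 3 (0.28 log units; within the scatter)). The step removes the six-membered aromatic ring of carbon only and replaces a group of 7 heavy atoms with an ethynyl group of 2 heavy atoms and a triple bond, so in this one pair the 4-fluorophenyl form gives the lower number and the stronger inhibition. No measurement offered here explains why this change weakens inhibition on these cells.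

The compounds shown leave open whether the loss of the ring, the smaller size or the triple bond accounts for the step, and a propyl chain or an unsubstituted benzyl group on the sulfur would begin to separate these. They also leave open whether the same step would appear when the phenyl-bearing ring nitrogen side of compound 2 is replaced by the substituted side chain of compound 3.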